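From compound 2 to compound 3: an expected step

A few compounds are considered here, and "the series" means these few. Any claim that something is new, unique, unknown or untested is made for them only; others in the source may bear on it.

compound 1 `O=c1sc2ccccc2n1CCCCCCN1CCN(CCn2c(=O)sc3ccccc32)CC1`: 2950 nM
compound 2 `O=c1sc2ccccc2n1CCCCCN1CCN(CCCn2c(=O)sc3ccccc32)CC1`: 1460 nM

In an assay on SW1353 cells (Homo sapiens) for inhibition, read by a luciferase reporter, with stated times of 30 min and 8 h (on this read-out lower numbers stand for stronger inhibition and higher numbers for weaker inhibition), compound 2 stands lowest of the two measured compounds at 1460 nM and compound 1 lies higher at 2950 nM by a gap beyond the usual scatter. Going by the values given here, compound 3 `O=c1sc2ccccc2n1CCCCCCN1CCN(CCCn2c(=O)sc3ccccc32)CC1` has no measurement yet. Its structural change from compound 2, (a group of 11 heavy atoms (8 carbon, 1 nitrogen, 1 oxygen, 1 sulfur; one five-membered aromatic ring with 2 hetero atoms, one six-membered aromatic ring of carbon only) in place of a group of 10 heavy atoms (7 carbon, 1 nitrogen, 1 oxygen, 1 sulfur; one five-membered aromatic ring with 2 hetero atoms, one six-membered aromatic ring of carbon only), on a saturated chain carbon, five bonds along the chain from an amine nitrogen in a ring), sits on a saturated chain carbon, five bonds along the chain from an amine nitrogen in a ring. Among the compounds with values here, no measured pair differs in one place, so the data offer no direct guide to this change. In this assay no step beyond the scatter is expected, with at most a slight rise in the number. The estimated step is a 1.2-fold higher number from compound 2 to compound 3 (0.07 log units; within the scatter) in this measurement. For compound 3 the expected value is 1700 nM, with an estimated range from 700 nM to 4000 nM overall.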

Compound 3, half-maximal inhibitory concentration: 2400 nM
Compound 3: middle estimate off by 1.4-fold (0.15 log units), on the low side; low and high end bracket the measured number.
By their numbers in this assay, from the lowest: compounds 2, 3 and 1 (each within the scatter of the next, the first and the last beyond it).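

In this assay, the group of 11 heavy atoms in place of the group of 10 heavy atoms gives a 1.6-fold higher number from compound 2 to compound 3 (0.22 log units; within the scatter) when the change sits on a saturated chain carbon, five bonds along the chain from an amine nitrogen in a ring. The same exchange gives a 1.2-fold lower number from compound 1 to compound 3 (0.09 log units; within the scatter) when it sits on a saturated chain carbon, two bonds along the chain from an amine nitrogen in a ring, so at neither place does this single change move the number beyond the scatter. No supporting evidence bears on this result.

The compounds shown leave open whether a longer chain at either place would give a step beyond the scatter. They also leave open what an amine or a carboxylic acid on the chain would do.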